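Cytotoxicity of a pyrazole series: from urea to benzamide

The source may hold more compounds than are shown below. What is called first, only, known or untested is meant among the compounds shown, and "the series" means these compounds.

The three measured compounds share a core that carries a pyridinyl group and a chloro-methoxyphenyl group on the pyrazole, with an amide or urea on the pendant aniline. Compound 1 `COc1cc(-c2nn(-c3cccc(NC(=O)c4ccc(Cl)c(C(F)(F)F)c4)c3)cc2-c2ccncc2)ccc1Cl` was tested in a functional assay on MCF7 cells (Homo sapiens) for inhibition, read by sulforhodamine B assay, with a stated time of 48 h (on this read-out higher numbers stand for lower toxicity in this test and lower numbers for higher toxicity in this test), and reached only the limit of the test, > 32500 nM. Compound 2 `O=C(Nc1cccc(-n2cc(-c3ccncc3)c(-c3ccc(Cl)c(O)c3)n2)c1)Nc1cc(C(F)(F)F)cc(C(F)(F)F)c1`, which carries a urea and a hydroxyl instead of the methoxy, gives 31500 nM in this assay. Compound 3 `COc1cc(-c2nn(-c3cccc(NC(=O)Nc4cccc(C(F)(F)F)c4)c3)cc2-c2ccncc2)ccc1Cl`, a urea bearing a (3-(trifluoromethyl)phenyl)amino group, also stands at a limit in this assay, > 50000 nM. Compound 3 therefore stands among the least toxic values shown, but as a limit and not as a number.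

Going by the values given here, the only measured step that touches compound 3 is a step that the two limits leave unreadable from compound 1 to compound 3, and it cannot be sized, since both ends sit at limits (the limit of > 32500 nM in this assay, at which 1 of the 3 values shown sits, and (the limit of > 50000 nM in this assay, at which 1 of the 3 values shown sits)). Among the compounds with values here, no measured step mirrors the change to compound 4 `COc1cc(-c2nn(-c3cccc(NC(=O)c4ccccc4)c3)cc2-c2ccncc2)ccc1Cl`, which is phenyl in place of (3-(trifluoromethyl)phenyl)amino on a carbonyl carbon. With all three measured values sitting at or near the upper edge of the test, the expectation for compound 4 is a step of about an at least 1.2-fold lower number from compound 3 to compound 4 (0.09 log units; that floor lies within the scatter) in this assay, most likely again a limit rather than a number. The estimate for compound 4 is 40000 nM, within 15000 nM to 100000 nM.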

Compound 4, concentration lethal to 50% of the cells: > 100000 nM
Compound 4: a limit, no number (the forecaster's own chance of this, stated with the estimate: 60%); at least 2.5-fold (0.39 log units) between middle value and limit.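

Compound 4 also stands at a limit, > 100000 nM in this assay. The steps to it from compound 1 and from compound 3 cannot be read, as each joins two limits. The compounds shown leave open how far phenyl, (3-(trifluoromethyl)phenyl)amino and 4-chloro-3-(trifluoromethyl)phenyl on the carbonyl carbon differ in toxicity in this test.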